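A few compounds are considered here, and "the series" means these few. Any claim that something is new, unique, unknown or untested is made for them only; others in the source may bear on it.

In a functional assay on a cell-free system (plasma, Oryctolagus cuniculus) for inhibition, with stated times of 5 min, 1 min and 6 min (a higher number here means a weaker inhibitor, a lower number a stronger inhibitor), compound 1 `CCOC(=O)c1c(C)nc(-c2cccc(C#N)c2)n1O` gives 17600 nM, compound 2 `CCOC(=O)c1c(C)nc(-c2cccc(C#N)c2)n1OC(C)C` gives 6740 nM, and compound 3 `CCOC(=O)c1c(C)nc(-c2cccc(C#N)c2)n1OCc1ccc(Cl)cc1` gives 6830 nM. Compound 3 therefore sits level with compound 2, within the scatter, and well under compound 1 on the numbers.

Compound 4 `CCOC(=O)c1c(C)nc(-c2cccc(C#N)c2)n1OCc1ccc(Br)cc1` differs from compound 3 by bromo in place of chloro on an aromatic carbon. The change is bromo in place of chloro on an aromatic carbon, para to a large group.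

For the measured compounds named here, no measured step exchanges one halogen for another, so the evidence is indirect. Substitution on the oxygen gave modest steps: a 2.6-fold lower number from compound 1 to compound 2 (0.42 log units; beyond the scatter) with isopropyl and a 2.6-fold lower number from compound 1 to compound 3 (0.41 log units; beyond the scatter) with 4-chlorobenzyl. The closest evidence is a 1.0-fold higher number from compound 2 to compound 3 (0.01 log units; within the scatter), an exchange of a whole group at that oxygen that stayed within the scatter. A smaller exchange at the far end of the 4-chlorobenzyl group is therefore not expected to move this assay beyond the scatter.

The expected step is a 1.1-fold lower number from compound 3 to compound 4 (0.02 log units; within the scatter), with no clear direction.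

Compound 4 is estimated at 6500 nM, with an expected range of 3500 nM to 12000 nM.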

Compound 4, half-maximal inhibitory concentration: 24600 nM
Beside the measured number, compound 4's estimate is 3.8-fold (0.58 log units) below it; the whole stated range lies below it.
By their numbers in this assay, from the lowest: compounds 2 and 3 (each within the scatter of the next); then compounds 1 and 4 (each within the scatter of the next).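

In this assay the far end of the benzyl group is not a silent place: bromo in place of chloro on an aromatic carbon, para to a large group, gives a 3.6-fold higher number from compound 3 to compound 4 (0.56 log units; beyond the scatter). The lower number seen with 4-chlorobenzyl on the oxygen therefore does not carry over to 4-bromobenzyl, which reads a 1.4-fold higher number from compound 1 to compound 4 (0.15 log units; within the scatter) and, against isopropyl, a 3.6-fold higher number from compound 2 to compound 4 (0.56 log units; beyond the scatter). Nothing measured here accounts for this difference between two halogens.

This single halogen pair leaves open whether the step belongs to bromo alone or extends to other groups at this place, such as fluoro, methyl or methoxy. Also open, going by these compounds, is how an amine or a carboxylic acid would read at the same place on the benzyl group.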